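This account rests on a few compounds, and the source may have more. Where it says the series, first, only, none or still open, it means among the compounds named here.

Measured compounds:
compound 1 `C=CCOc1ccc2c(NCCN(C)C)ccnc2c1` — 1530 nM
compound 2 `CN(C)CCCNc1ccnc2cc(OCc3ccc(F)cc3)ccc12` — 2540 nM
compound 3 `CCOc1ccc2c(NCCCN(C)C)ccnc2c1` — 8540 nM

In a functional assay on DLD-1 cells (Homo sapiens) for cytotoxicity, read by MTT assay, with a stated time of 48 h (a lower number here means a stronger inhibitor, a higher number a weaker inhibitor), compound 3 gives the highest number of the three, and its gaps to compound 2 and to compound 1 both lie beyond the scatter, so it is the weakest inhibitor of the measured set. Compound 4 `C=CCOc1ccc2c(NCCCN(C)C)ccnc2c1` has not yet been measured. It differs from compound 3 in one place: vinyl in place of methyl on a saturated chain carbon bound to an oxygen on an aromatic ring.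

Within the data shown here, one measured step bears on this position. The step of a 3.4-fold higher number from compound 2 to compound 3 (0.53 log units; beyond the scatter) shows that what sits on this saturated chain carbon bound to the aryl oxygen matters in this assay, with the smallest group giving the highest number. Compound 1 also carries an allyloxy group, though it differs from compound 4 elsewhere as well; compound 1 gives 1530 nM, a lower number than compound 3. Taken together, the move from methyl to vinyl is therefore expected to lower the number by a modest margin, beyond the scatter but not as far as the return of the 4-fluorophenyl would suggest.

Compound 4 is accordingly estimated to give 2800 nM in this assay, within a range of 1100 nM to 7000 nM, an expected step of a 3.1-fold lower number from compound 3 to compound 4 (0.48 log units; beyond the scatter).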

Compound 4, half-maximal inhibitory concentration: 5180 nM
Compound 4: the middle estimate sits 1.9-fold (0.27 log units) below what was measured; measured number inside the range.
By their numbers in this assay, from the lowest: compounds 1 and 2 (each within the scatter of the next); then compounds 4 and 3 (each within the scatter of the next).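

In this assay vinyl in place of methyl gives a 1.6-fold lower number from compound 3 to compound 4 (0.22 log units; within the scatter), so on this saturated chain carbon bound to an oxygen on an aromatic ring the two groups cannot be told apart, and the added double bond brings no change that can be read. Vinyl in place of 4-fluorophenyl gives a 2.0-fold higher number from compound 2 to compound 4 (0.31 log units; beyond the scatter), which, together with the vinyl and methyl result, sets 4-fluorophenyl apart from both smaller groups at this place, though only modestly. Among these compounds, with the allyloxy group held constant, (dimethylamino)methyl in place of dimethylamino gives a 3.4-fold higher number from compound 1 to compound 4 (0.53 log units; beyond the scatter), so the low number of compound 1 goes with its amine chain and not with the allyloxy group, which the earlier compounds could not separate.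

No measurement offered here explains any of these steps. The compounds shown leave open whether an unsubstituted phenyl would behave like 4-fluorophenyl at this place, and whether a longer chain or a cyclic amine such as piperidine in place of dimethylamino would extend the effect seen with the amine chain.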